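The compounds below may be only part of what the source reports. "The series", "measured", "known", "first", "only" and "open" are said of these compounds alone.

Four compounds are in view: compound 1 (`O=C(NCc1cccnc1)Nc1ccc(CN2C(=O)c3ccccc3C2=O)cc1`), compound 2 (`CCC(=O)NC(C)(C)c1ccc(NC(=O)[C@H]2C[C@@H]2c2cccnc2)cc1`), compound 3 (`C[C@H](NC(=O)CC(F)(F)F)c1ccc(NC(=O)[C@H]2C[C@@H]2c2cccnc2)cc1`) and compound 4 (`C[C@H](NC(=O)c1ccccn1)c1ccc(NC(=O)[C@H]2C[C@@H]2c2cccnc2)cc1`). In a functional assay on COR-L23 cells (Homo sapiens) for antiproliferative activity, read by CellTiter-Glo, with a stated time of 4 days (a higher number here means a weaker inhibitor, a lower number a stronger inhibitor), compound 1 has "not determined" (no result reported) and so offers no number to compare. For the measured compounds named here, compound 2 gives 2310 nM while compound 3 gives 18 nM and thus holds the lowest number so far, with a gap well beyond the scatter of repeated measurements.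

Compound 4 differs from compound 3 in one place: pyridin-2-yl stands in place of 2,2,2-trifluoroethyl on a carbonyl carbon (pyridin-2-yl in place of 2,2,2-trifluoroethyl on a carbonyl carbon). Going by the values given here, no measured pair here shows this exchange on its own, so any forecast is uncertain. Compound 2, at 2310 nM, shows how far a number can lie from that of compound 3, so a wide range is kept. A modest move towards a higher number, meaning a somewhat weaker inhibitor in this assay, is expected, and the estimated step of a 1.7-fold higher number from compound 3 to compound 4 (0.22 log units; within the scatter) is only a rough guess. The expected value for compound 4 is 30 nM with an estimated range from 7 nM to 130 nM as its likely span.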

Compound 4, half-maximal inhibitory concentration: 46 nM
The estimate for compound 4 lay 1.5-fold (0.19 log units) below the measured number; the measured number falls inside the stated range.
By their numbers in this assay, from the lowest: compound 3; then compound 4; then compound 2.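

In this assay, for the compounds shown here, this is the first comparison in which only the group on the carbonyl carbon changes: replacing 2,2,2-trifluoroethyl with pyridin-2-yl gives a 2.6-fold higher number from compound 3 to compound 4 (0.41 log units; beyond the scatter). The change is modest, so this position accepts a six-membered aromatic ring in place of the open fluorinated chain, and compound 4 keeps a number of 46 nM. No measurement offered here explains why the two groups differ.

The compounds shown leave open whether the ring nitrogen of pyridin-2-yl matters, which a plain phenyl ring on the same carbonyl carbon would help to settle. They also leave open how a simple ethyl chain, without its fluorines, or a saturated ring such as cyclohexyl would compare with these two groups.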